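The source may hold more compounds than are shown below. What is called first, only, known or untested is meant among the compounds shown, and "the series" means these compounds.

Compound 1, `CCC1(CCCCN2CCN(c3cccc(Cl)c3)CC2)C(=O)Nc2ccccc21`, was studied in a functional assay on the whole organism (strain NMRI) with Mus musculus as the target, in the forced swim test, with stated times of 30 min, 4 min and 6 min; on this read-out higher numbers stand for an effect only at larger amounts of compound and lower numbers for an effect already at smaller amounts. In this assay compound 1 gives > 10 mg/kg, which is a limit of the assay and not a number. The limit stands as the limit of > 10 mg/kg in this assay, at which 1 of the 3 values shown sits. Two further compounds share the same core with other substituents: compound 2, `CCC1(CCCCN2CCN(c3cccc(Cl)c3)CC2)C(=O)Nc2cc(F)c(Cl)cc21`, gives "not determined" (no result reported) in this assay, and compound 3, `CCC1(CCCCN2CCN(c3ccc(Cl)cc3)CC2)C(=O)Nc2cc(F)c(Cl)cc21`, gives "not determined" (no result reported). Going by the values given here, no step between two measured compounds can be drawn from these entries, so the position of compound 1 rests on its limit alone.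

Compound 4, `CCC1(CCCCN2CCN(c3ccc(Cl)c(Cl)c3)CC2)C(=O)Nc2ccccc21`, has not yet been measured in this assay. Compared with compound 1, it carries chloro in place of hydrogen on an aromatic carbon. Among the compounds with values here, the data hold no measured step that would say how such a chloro affects the minimum effective dose.

Compound 4 is therefore expected to sit close to compound 1, with a step from compound 1 to compound 4 of about a number no higher from compound 1 to compound 4 (the limit leaves the size open), meaning no change beyond the scatter or a slightly smaller amount needed. The estimate for compound 4 in this assay is 10 mg/kg, with a range from 3 mg/kg to 30 mg/kg; since compound 1 gives only a limit, a limit for compound 4 is also expected as a likely outcome.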

Compound 4, minimum effective dose: > 10 mg/kg
Compound 4: a limit, no number; the forecaster's own chance of this, stated with the estimate: 60%; the middle value lies on the limit itself.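

Compound 1 and compound 4 both end at a limit of this assay, which is not a number, so no step between them can be read: the limit of > 10 mg/kg in this assay, at which 2 of the 4 values shown sit.

The compounds shown leave open what minimum effective dose either compound has, and whether chloro in place of hydrogen on the aromatic carbon changes it at all.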